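Replacing 4-chlorophenyl by phenethyl on a sulfur

The source may report more compounds than this note shows. Statements on the series, on what has been measured and on what is new or still open speak of the compounds shown alone.

Of the compounds shown here, two have so far been tested in a functional assay on A-375 cells (Homo sapiens) for inhibition, read by CCK-8 assay, with a stated time of 72 h, tested at 8 uM; a higher number here means more inhibition of growth at the concentration tested, a lower number less inhibition of growth. Compound 1 `Nc1ccccc1NC(=O)/C=C/c1ccc(CSc2ccc(Cl)cc2)cc1` gives 48.2% in this assay, the lower of the two numbers. Compound 2 `Nc1ccccc1NC(=O)c1ccc(CSc2nccc(C(F)(F)F)n2)cc1` differs from compound 1 in several places at once. In this assay compound 2 gives 80.1%, a number that lies beyond the usual scatter above that of compound 1; with several differences at once, the two values by themselves do not tell which change is responsible.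

Compound 3 `Nc1ccccc1NC(=O)/C=C/c1ccc(CSCCc2ccccc2)cc1` has not yet been measured. It differs from compound 1 in a single place: phenethyl in place of 4-chlorophenyl on a sulfur. Among the compounds with values here, no measured pair shows what changing this group on the sulfur does, so the size and direction of the step can only be judged from compound 1 itself. The expectation is that compound 3 stays near its starting point, with the step of a number 3.2 percentage points lower from compound 1 to compound 3 (within the scatter) expected to fall within the scatter, in either direction. Compound 3 is therefore estimated to give 45% in this assay, with a range from 25% to 65%.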

Compound 3, percent growth inhibition at one concentration: 37.4%
Compound 3: middle estimate off by 7.6 percentage points, on the high side; low and high end bracket the measured number.
By their numbers in this assay, from the lowest: compound 3; then compound 1; then compound 2.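

In this assay, within the data shown here, phenethyl in place of 4-chlorophenyl on a sulfur gives a number 10.8 percentage points lower from compound 1 to compound 3 (beyond the scatter), and this is the first measured pair that differs in one place only. The step shows that growth inhibition in this series responds to the group on this sulfur, even though both groups hold one six-membered aromatic ring of carbon only and neither has a hydrogen-bond donor or acceptor, so those counts alone do not settle the number. No measurement shown here explains the step.

On these data alone, the change removes the chlorine and adds the saturated chain of phenethyl in one move, so it remains open which of the two matters, and a plain phenyl on the sulfur would help to separate them. Also open are the effect of an amine or a carboxylic acid on this part of the molecule, and which of the several differences between compound 1 and compound 2 accounts for the gap between their numbers.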